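Swapping the ethoxy for bromine on the hydroxyphenyl ring

The compounds below may be only part of what the source reports. "The series", "measured", "known", "first", "only" and "open" are said of these compounds alone.

Of the compounds shown here, three sharing one core have been measured in a functional assay on PC-3 cells (Homo sapiens) for antiproliferative activity, read by MTT assay, with a stated time of 72 h; on this read-out lower numbers stand for stronger inhibition and higher numbers for weaker inhibition. Compound 1 `O=C(N/N=C/c1ccccn1)c1cccc(S(=O)(=O)N2CCOCC2)c1` gives 88100 nM. Compound 2 `O=C(N/N=C/c1ccccc1O)c1cccc(S(=O)(=O)N2CCOCC2)c1` gives 13800 nM, and compound 3 `CCOc1cccc(/C=N/NC(=O)c2cccc(S(=O)(=O)N3CCOCC3)c2)c1O` gives 15300 nM, the second highest of the three numbers. The steps of a 6.4-fold lower number from compound 1 to compound 2 (0.81 log units; beyond the scatter) and a 5.8-fold lower number from compound 1 to compound 3 (0.76 log units; beyond the scatter) were modest, while the step of a 1.1-fold higher number from compound 2 to compound 3 (0.04 log units; within the scatter) was within the scatter. Compound 4 `O=C(N/N=C/c1cc(Br)ccc1O)c1cccc(S(=O)(=O)N2CCOCC2)c1` is not yet measured; it differs from compound 3 by 5-bromo-2-hydroxyphenyl in place of 3-ethoxy-2-hydroxyphenyl on a carbon with a double bond to nitrogen. Since the ethoxy group made no difference beyond the scatter and the 2-hydroxyphenyl part remains, the most useful comparison is the step from compound 2 to compound 3, and a step of a 1.3-fold lower number from compound 3 to compound 4 (0.11 log units; within the scatter) within the scatter is expected. Compound 4 is therefore estimated at 12000 nM, with a range from 4500 nM to 32000 nM.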

Compound 4, half-maximal inhibitory concentration: 7230 nM
Compound 4: the middle estimate sits 1.7-fold (0.22 log units) above what was measured; the range from low to high includes it.
By their numbers in this assay, from the lowest: compounds 4, 2 and 3 (each within the scatter of the next, the first and the last beyond it); then compound 1.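

Within the data shown here, replacing the ring of compound 3 with 5-bromo-2-hydroxyphenyl gives, in this assay, a 2.1-fold lower number from compound 3 to compound 4 (0.33 log units; beyond the scatter), the first step between two hydroxyphenyl compounds to clear the scatter. Bromine on the plain 2-hydroxyphenyl ring stays within the scatter, with a 1.9-fold lower number from compound 2 to compound 4 (0.28 log units; within the scatter), so this set cannot credit bromine itself with a real effect. The distance from pyridin-2-yl now reaches a large step, a 12-fold lower number from compound 1 to compound 4 (1.09 log units; beyond the scatter), and no outside data explain these steps. On these data alone, whether chlorine or an amine in place of the bromine would shift the number remains open.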